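From Bromo to Iodo on the Shared Core

The compounds below may be only part of what the source reports. "The series", "measured", "known", "first", "only" and "open" are said of these compounds alone.

Going by the values given here, in a functional assay on SF-295 cells (Homo sapiens) for inhibition, read by sulforhodamine B assay, with a stated time of 48 h (on this read-out lower numbers stand for stronger inhibition of growth and higher numbers for weaker inhibition of growth), compound 1 (`Cc1ccc(NC(=O)/C=C/c2ccccc2)c(C(N)=O)c1`) gives 3140 nM while compound 2 (`NC(=O)c1cc(Br)ccc1NC(=O)/C=C/c1ccccc1`) gives 625 nM as the lower of the two numbers so far. Compound 3 (`NC(=O)c1cc(I)ccc1NC(=O)/C=C/c1ccccc1`) carries iodo in place of bromo on an aromatic carbon, meta to a carbamoyl group and para to a large group (iodo in place of bromo on an aromatic carbon). Among the compounds with values here, the one measured step that bears on this change, with bromo in place of methyl on the same aromatic carbon, is a 5.0-fold lower number from compound 1 to compound 2 (0.70 log units; beyond the scatter) and it is a different swap, so only a small further move to a lower number is expected in this assay, probably within the scatter. The estimated step is a 1.3-fold lower number from compound 2 to compound 3 (0.10 log units; within the scatter) and no more than that is expected. For compound 3 the estimated value is 500 nM with an expected range of 200 nM to 1300 nM in repeat measurements.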

Compound 3, concentration for 50% growth inhibition: 350 nM
For compound 3 the middle estimate is 1.4-fold (0.15 log units) above the measured one; the measured number falls inside the stated range.
By their numbers in this assay, from the lowest: compounds 3 and 2 (each within the scatter of the next); then compound 1.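

In this assay putting iodo in place of bromo on this aromatic carbon gives a 1.8-fold lower number from compound 2 to compound 3 (0.25 log units; within the scatter) and so leaves the two halogens indistinguishable at this position. Set against the methyl group, iodo gives a 9.0-fold lower number from compound 1 to compound 3 (0.95 log units; beyond the scatter) and thereby shows that the separation from methyl holds for a second halogen and not for bromo alone. Nothing available here accounts for how this carbon responds to these swaps.

Still open, on these data alone, is what chloro or fluoro would give on this same carbon, and whether a group of another kind there, such as an amine, a carboxylic acid or a methoxy group, would stay with the halogens or with methyl. The compounds shown also leave open whether the carbamoyl group has to remain for the halogens to keep their numbers.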